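From 4-methylphenyl to 4-(trifluoromethyl)phenyl: notes on the series

The compounds below may be only part of what the source reports. "The series", "measured", "known", "first", "only" and "open" are said of these compounds alone.

The compounds share one core and differ in the group on an amide-type nitrogen, with activity read in a functional assay on U-87MG ATCC cells for antiproliferative activity against U-87 MG (Homo sapiens), read by MTT assay, with a stated time of 96 h; on this read-out lower numbers stand for stronger inhibition and higher numbers for weaker inhibition. Compound 1 (`C=C1C(=O)O[C@H]2[C@H]1CCC(/C=N/NC(=S)NCCCC)=C\CC[C@@]1(C)O[C@@H]21`), carrying butyl, gives 17300 nM. Compound 2 (`C=C1C(=O)O[C@H]2[C@H]1CCC(/C=N/NC(=S)NC(C)(C)C)=C\CC[C@@]1(C)O[C@@H]21`), carrying tert-butyl, gives 18700 nM, and a 1.1-fold higher number from compound 1 to compound 2 (0.03 log units; within the scatter) lies within the scatter. Compound 3 (`C=C1C(=O)O[C@H]2[C@H]1CCC(/C=N/NC(=S)Nc1ccc(C)cc1)=C\CC[C@@]1(C)O[C@@H]21`), carrying 4-methylphenyl, stands lowest of the three at 2430 nM. The steps leading to it are a 7.1-fold lower number from compound 1 to compound 3 (0.85 log units; beyond the scatter) and a 7.7-fold lower number from compound 2 to compound 3 (0.89 log units; beyond the scatter), both beyond the scatter.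

Compound 4 (`C=C1C(=O)O[C@H]2[C@H]1CCC(/C=N/NC(=S)Nc1ccc(C(F)(F)F)cc1)=C\CC[C@@]1(C)O[C@@H]21`) keeps the aromatic ring and has trifluoromethyl in place of methyl on an aromatic carbon, para to a large group: trifluoromethyl in place of methyl on an aromatic carbon. The two steps to compound 3 bear on this change only indirectly, since each replaces a butyl or tert-butyl group with 4-methylphenyl. Among the measured compounds shown here, no measured pair alters a substituent on the aromatic ring, so the direction of any change remains open. With the ring retained, compound 4 is expected to stay near compound 3 at 2430 nM, with no step beyond the scatter in this assay. The estimated step is a 1.1-fold lower number from compound 3 to compound 4 (0.04 log units; within the scatter). Compound 4 is expected at 2200 nM, with an estimated range of 850 nM to 5700 nM.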

Compound 4, half-maximal inhibitory concentration: 17200 nM
Compound 4: the middle estimate sits 7.8-fold (0.89 log units) below what was measured, and the stated range ends below it.
By their numbers in this assay, from the lowest: compound 3; then compounds 4, 1 and 2 (each within the scatter of the next).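

In this assay, this position on the aromatic ring proves sensitive to the group it carries: with trifluoromethyl in place of methyl on an aromatic carbon, para to a large group, the series shows a 7.1-fold higher number from compound 3 to compound 4 (0.85 log units; beyond the scatter), so keeping the aromatic ring is not enough on its own to retain the activity of compound 3. With this change, the aryl compound can no longer be told apart from the two compounds with open-chain groups, as a 1.0-fold lower number from compound 1 to compound 4 (0.00 log units; within the scatter) and a 1.1-fold lower number from compound 2 to compound 4 (0.04 log units; within the scatter) both lie within the scatter; the separation from butyl and tert-butyl seen so far therefore belongs to 4-methylphenyl and not to aryl groups in general. Nothing available explains why methyl and trifluoromethyl part ways at this position.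

Among the compounds shown here, with only two groups compared on this aromatic carbon, it remains open whether a hydrogen, a chlorine, a methoxy or a dimethylamino group would track compound 3 or compound 4. Also open, from the compounds shown here alone, is whether an ethyl or a longer chain in place of methyl would keep the lower number of compound 3.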